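Ethyl on the pyridine ring of compound 1: expectation for compound 4

The source may report more compounds than this note shows. Statements on the series, on what has been measured and on what is new or still open speak of the compounds shown alone.

Measured so far:
compound 1 `CN1CCC[C@H]1COc1cccnc1` 100%
compound 2 `Cc1ncccc1OC[C@@H]1CCCN1C` 26.7%
compound 3 `Cc1ccncc1OC[C@@H]1CCCN1C` 73.9%

In an assay on K177 cells with Neuronal acetylcholine receptor; alpha4/beta2 (Homo sapiens) as the target (a higher number here means a larger maximal response, a lower number a smaller maximal response), compound 1 stands highest of the three; compound 3 comes nearest and compound 2 lies furthest from it. Both measured steps put a methyl in place of hydrogen on an aromatic carbon, each at its own position: a number 73.3 percentage points lower from compound 1 to compound 2 (beyond the scatter) and a number 26.1 percentage points lower from compound 1 to compound 3 (beyond the scatter). Compound 4 `CCc1cncc(OC[C@@H]2CCCN2C)c1` is not yet measured; it differs from compound 1 as follows: ethyl in place of hydrogen on an aromatic carbon. Neither methyl step sits at the place where the ethyl enters, so they bear only in kind, and both point downward. A loss beyond the scatter is therefore expected, of the size a number 40 percentage points lower from compound 1 to compound 4 (beyond the scatter). Compound 4 is expected to give 60%, within 30% to 95%.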

Compound 4, largest response reached (reported as maximum), in percent of the reference or control that the assay uses: 33.7%
For compound 4 the middle estimate is 26.3 percentage points above the measured one; the range from low to high includes it.
By their numbers in this assay, from the lowest: compounds 2 and 4 (each within the scatter of the next); then compound 3; then compound 1.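

At this place, two atoms from the ring nitrogen, ethyl in place of hydrogen gives a number 66.3 percentage points lower from compound 1 to compound 4 (beyond the scatter) in this assay and so costs much of the maximal response of compound 1. For the compounds shown here, the earlier steps showed losses only for methyl at other ring places, so this is the first sign that this place also gives a loss, here with ethyl. The data offer no explanation for the size of this step.

As far as these compounds go, whether methyl, chlorine or a methoxy group at this same place would keep more of the response remains open. The loss therefore cannot yet be divided between the place itself and the ethyl group.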